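A few compounds are considered here, and "the series" means these few. Any claim that something is new, unique, unknown or untested is made for them only; others in the source may bear on it.

Measured compounds:
Compound 1, `Nc1cccc(Nc2cc(Cl)cc(Cl)c2)n1`. In an assay on cells for inhibition of S-adenosylmethionine decarboxylase proenzyme (Homo sapiens), read by mass spectrometry, at pH 7.2 (on this read-out higher numbers stand for weaker inhibition and lower numbers for stronger inhibition), compound 1 gives > 180000 nM, which is a limit of the assay and not a number.
Compound 2, `COc1ccc(-c2cc(Cl)cc(Nc3cc(C)nc(N)n3)c2)cc1`. In this assay compound 2 gives > 180000 nM, again a limit.
Compound 3, `CC(=O)c1ccc(-c2cc(Cl)cc(Nc3cc(C)nc(N)n3)c2)cc1`. In this assay compound 3 gives > 21000 nM, also a limit.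

Among the compounds with values here, compound 2 thus stands at the limit of > 180000 nM in this assay, at which 2 of the 3 values shown sit, and the only single-point step recorded, a step that the two limits leave unreadable from compound 2 to compound 3, ends at the limit of > 21000 nM in this assay, at which 1 of the 3 values shown sits, and gives no readable size. Compound 4, `Cc1cc(Nc2cc(Cl)cc(-c3cncs3)c2)nc(N)n1`, differs from compound 2 by 1,3-thiazol-5-yl in place of 4-methoxyphenyl on an aromatic carbon. Within the data shown here, no measured step bears directly on this change; the one step recorded is unreadable, and every value so far is a limit rather than a number. The expectation in this assay is therefore no step beyond the scatter in either direction, with compound 4 most likely again reported only as a limit. The estimate for compound 4 is 150000 nM, range 30000 nM to 600000 nM. The step this estimate implies, an at least 1.2-fold lower number from compound 2 to compound 4 (0.07 log units; that floor lies within the scatter), is expected to lie within the scatter.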

Compound 4, half-maximal inhibitory concentration: > 21000 nM
Compound 4: only a limit was reported; the forecaster's own chance of this, stated with the estimate: 70%; the middle value is on the limit's open side.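

Compound 2 gives > > 180000 nM, a limit. Compound 4 gives > 21000 nM, also a limit, so the step between these two compounds cannot be read. Left open is whether 1,3-thiazol-5-yl and 4-methoxyphenyl differ at all in inhibition; every value shown is a limit.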